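From phenyl to cyclooctyl on the amide nitrogen

This account rests on a few compounds, and the source may have more. Where it says the series, first, only, none or still open, it means among the compounds named here.

In a functional assay on BaF3 cells (Mus musculus) for antiproliferative activity, read by CCK-8 assay and cell counting, with a stated time of 76 h (on this read-out higher numbers stand for weaker inhibition and lower numbers for stronger inhibition), compound 2 (`COc1cc2nccc(Oc3ccc(Nc4nn(C)cc4C(=O)Nc4ccccc4)cc3)c2cc1C(N)=O`) stands only at a limit (> 10000 nM). Compound 1 (`COc1cc2nccc(Oc3ccc(Nc4nn(C)cc4C(=O)NCc4ccccc4)cc3)c2cc1C(N)=O`) is also only a limit (> 10000 nM). Two of the three measured compounds therefore sit at the same ceiling (the limit of > 10000 nM in this assay, at which 2 of the 3 values shown sit), and the step between them gives no size (a step that the two limits leave unreadable from compound 1 to compound 2). Compound 3 (`COc1cc2nccc(Oc3ccc(Nc4nn(C)cc4C(=O)NC4CCCCC4)cc3)c2cc1C(N)=O`) alone gives a number (4800 nM).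

Compound 4 (`COc1cc2nccc(Oc3ccc(Nc4nn(C)cc4C(=O)NC4CCCCCCC4)cc3)c2cc1C(N)=O`) carries a single change from compound 2 (cyclooctyl in place of phenyl on an amide-type nitrogen), cyclooctyl in place of phenyl on an amide-type nitrogen. For the measured compounds named here, the closest precedent is cyclohexyl in place of phenyl (an at least 2.0-fold lower number from compound 2 to compound 3 (0.31 log units; beyond the scatter)). Cyclohexyl in place of benzyl reads the same way (an at least 2.0-fold lower number from compound 1 to compound 3 (0.31 log units; beyond the scatter)). Going by the values given here, both are lower bounds, and no measured compound tests ring size. A modest move towards stronger inhibition is therefore expected (an at least 2.5-fold lower number from compound 2 to compound 4 (0.39 log units; beyond the scatter)), and a result at the limit remains possible. The estimated value for compound 4 is (4000 nM), with an expected range from (1000 nM) to (12000 nM).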

Compound 4, half-maximal inhibitory concentration: 3210 nM
Compound 4: middle estimate off by 1.2-fold (0.10 log units), on the high side; measured number inside the range.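

In this assay, cyclooctyl on the amide-type nitrogen shows that moving off the ceiling does not depend on cyclohexyl alone: the series now has an at least 3.1-fold lower number from compound 2 to compound 4 (0.49 log units; beyond the scatter) and an at least 3.1-fold lower number from compound 1 to compound 4 (0.49 log units; beyond the scatter). Enlarging the ring gives no readable change, with a 1.5-fold lower number from compound 3 to compound 4 (0.17 log units; within the scatter), so compound 3 and compound 4 cannot be ordered and no ring-size preference appears among the non-aromatic rings shown. The steps from compound 1 and compound 2 give only lower bounds on size, and the step between those two compounds cannot be read: the limit of > 10000 nM in this assay, at which 2 of the 4 values shown sit.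

From the compounds shown here alone, whether a smaller ring such as cyclobutyl or an open chain such as octyl would give a similar read-out remains open. Also open, going by these compounds, is how a cyclohexyl ring carrying an amine or a carboxylic acid would read at this position.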